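Shortening the alkoxy chain of compound 1

The compounds below may be only part of what the source reports. "The series", "measured", "known", "first", "only" and "open" are said of these compounds alone.

Going by the values given here, compound 1 `CCCCCCOc1ccc2c(Cl)ccnc2c1` gives 2440 nM in a functional assay on HCT-116 cells (Homo sapiens) for cytotoxicity, read by MTT assay, with a stated time of 48 h (on this read-out higher numbers stand for weaker inhibition and lower numbers for stronger inhibition), the highest of the three numbers so far. Compound 2 `CCCCCCOc1ccc2c(NCCN(C)C)ccnc2c1` gives 850 nM, and compound 3 `CN(C)CCCNc1ccnc2cc(OCc3ccc(F)cc3)ccc12` gives 740 nM. Among the compounds with values here, the only single-point step measured so far, a 2.9-fold lower number from compound 1 to compound 2 (0.46 log units; beyond the scatter), exchanges the substituent on the aromatic carbon and leaves the alkoxy chain untouched. Compound 4 `CCCCOc1ccc2c(Cl)ccnc2c1` differs from compound 1 by hydrogen in place of ethyl on a saturated chain carbon, four bonds along the chain from an oxygen on an aromatic ring. Within the data shown here, no measured step bears on this change; compound 1 and compound 3 differ in chain and in aromatic substituent at once, so their values cannot separate the two. The estimated step of a 1.2-fold higher number from compound 1 to compound 4 (0.09 log units; within the scatter) is therefore expected to stay within the scatter. Compound 4 is estimated at 3000 nM, range 1200 nM to 7500 nM, in this assay.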

Compound 4, half-maximal inhibitory concentration: 2740 nM
Estimate against measurement, compound 4: 1.1-fold (0.04 log units) above; low and high end bracket the measured number.
By their numbers in this assay, from the lowest: compounds 3 and 2 (each within the scatter of the next); then compounds 1 and 4 (each within the scatter of the next).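

In this assay, going by these compounds alone, the step of a 1.1-fold higher number from compound 1 to compound 4 (0.05 log units; within the scatter) is the first measured on the alkoxy chain, and it lies within the scatter. With chloro held in place on the aromatic carbon, hydrogen in place of ethyl at this chain position leaves the number unresolved from that of compound 1, so removing these two carbons shows no measurable effect in this pair. Still open, as far as these compounds go, is whether the same change behaves alike with the (2-(dimethylamino)ethyl)amino group of compound 2 in place of chloro, and what a longer chain would give. No available evidence accounts for this result.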